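Working notes: methoxy in place of ethyl

This account rests on a few compounds, and the source may have more. Where it says the series, first, only, none or still open, it means among the compounds named here.

compound 1 `COc1ccc(Nc2ncnc3cc(NC(=O)CCCCCCC(=O)NO)sc23)c(C)c1` gives 1980 nM in a functional assay on RPMI-8226 cells (Homo sapiens) for antiproliferative activity, read by radiometric assay, with a stated time of 72 h; on this read-out lower numbers stand for stronger inhibition and higher numbers for weaker inhibition
compound 2 `CCc1ccc(Nc2ncnc3cc(NC(=O)CCCCCCC(=O)NO)sc23)cc1` gives 2540 nM in this assay

Compound 2 stands within the scatter of compound 1, so the two values are not separated. Compound 3 `COc1ccc(Nc2ncnc3cc(NC(=O)CCCCCCC(=O)NO)sc23)cc1` differs from compound 2 by methoxy in place of ethyl on an aromatic carbon, para to a large group methoxy in place of ethyl on an aromatic carbon and by nothing else. Among the measured compounds shown here, the one measured step that bears on this, a 1.3-fold higher number from compound 1 to compound 2 (0.11 log units; within the scatter) and thus within the scatter, replaces 4-methoxy-2-methylphenyl with 4-ethylphenyl. No step beyond the scatter is therefore expected in this assay for this change. The expected step is a 1.2-fold lower number from compound 2 to compound 3 (0.06 log units; within the scatter) and it should stay within the scatter. Compound 3 is estimated at 2200 nM (expected range 1000 nM to 4500 nM).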

Compound 3, half-maximal inhibitory concentration: 1840 nM
Beside the measured number, compound 3's estimate is 1.2-fold (0.08 log units) above it; measured number inside the range.
By their numbers in this assay, from the lowest: compounds 3, 1 and 2 (each within the scatter of the next).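

In this assay, methoxy in place of ethyl on an aromatic carbon, para to a large group, gives a 1.4-fold lower number from compound 2 to compound 3 (0.14 log units; within the scatter), so the two groups are not separated at this position. Hydrogen in place of methyl on an aromatic carbon now has a direct reading of its own, a 1.1-fold lower number from compound 1 to compound 3 (0.03 log units; within the scatter), and that methyl is not separated from hydrogen either. All three values therefore lie within the scatter of their neighbours. Going by these compounds, an amine, a carboxylic acid or a longer chain on the same aromatic carbon remains open, as does whether any group there gives a step beyond the scatter. No available evidence bears on why these values lie so close.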